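The compounds below may be only part of what the source reports. "The series", "measured", "known", "first", "only" and "open" are said of these compounds alone.

Measured compounds in an assay on isolated protein for inhibition of cytosolic endo-beta-N-acetylglucosaminidase (Homo sapiens), tested at 1000 uM; a lower number here means less inhibition, a higher number more inhibition at the concentration tested (going by the name of the read-out):
- compound 1 `O=C(O)[C@@H]1NC[C@@H](O)[C@@H](O)[C@H]1O`, 26%
- compound 2 `O=C(O)[C@H]1NC[C@@H](O)[C@H](O)[C@@H]1O`, 42%
- compound 3 `O=C(O)[C@@H]1NC[C@@H](O)[C@@H](O)[C@@H]1O`, 2.1%

Compound 3 stands lowest of the three numbers in this assay; compound 1 sits nearest to it and compound 2 furthest, both higher by steps beyond the scatter. All three compounds share the same atoms and bonds and differ only in configuration as drawn (the fact that compounds 1 and 2 differ only in the configuration as drawn, (the fact that compounds 1 and 3 differ only in the configuration as drawn), (the fact that compounds 2 and 3 differ only in the configuration as drawn)).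

Compound 4 `O=C(O)[C@@H]1NC[C@@H](O)[C@H](O)[C@@H]1O` is not yet measured. Against compound 3 the change is the two compounds have the same atoms and bonds and differ only in configuration as drawn: 1 of 4 stereo elements differ; a stereocentre at a saturated ring carbon is drawn R in compound 3 and S in compound 4. The measured steps that bear on a single change of configuration are a number 23.9 percentage points lower from compound 1 to compound 3 (beyond the scatter) and, across more centres, a number 16 percentage points higher from compound 1 to compound 2 (beyond the scatter) and a number 39.9 percentage points lower from compound 2 to compound 3 (beyond the scatter). Each change of configuration in this set moved the number beyond the scatter, and a single flip carried a modest step. Since compound 3 is already at the bottom of the range, the expected step is upward: compound 4 is expected to show a number 19.9 percentage points higher from compound 3 to compound 4 (beyond the scatter). Compound 4 is thus estimated at 22%, within a range from 2% to 45%.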

Compound 4, a percentage reported as inhibition, at one concentration (the size of the read-out at that concentration, not a potency): 0.8%
Compound 4: middle estimate off by 21.2 percentage points, on the high side; measured number outside the range, below it.
By their numbers in this assay, from the lowest: compounds 4 and 3 (each within the scatter of the next); then compound 1; then compound 2.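

In this assay, a single change of configuration does not always give a readable shift, as the step is a number 1.3 percentage points lower from compound 3 to compound 4 (within the scatter), the first single flip in the series to stay within the scatter. Compound 4 also sits one flip from compound 2, yet that flip gives a number 41.2 percentage points lower from compound 2 to compound 4 (beyond the scatter), so the size of a single flip varies widely within these compounds, while the two-centre change gives a number 25.2 percentage points lower from compound 1 to compound 4 (beyond the scatter). The large step can be traced to configuration alone, with no change of atoms or bonds: the fact that compounds 2 and 4 differ only in the configuration as drawn.

On these data alone, whether the flip from compound 3 to compound 4 would stay silent on a core carrying a hydroxymethyl group in place of the carboxylic acid remains open. A reading at one concentration also leaves the potency of all four compounds undefined.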